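The compounds below may be only part of what the source reports. "The series", "measured", "known", "first", "only" and "open" are said of these compounds alone.

Compound 3 `CCOC(=O)CCCCCOc1cccc(CN(C(=O)c2ccc(-c3cccc(NC(C)=O)c3)cc2)C(C)C)c1` is one of three related compounds already tested in an ADME assay on HepG2 cells (Homo sapiens) for cytotoxicity, read by CellTiter-Glo and resazurin assay, with a stated time of 72 h; a lower number here means that less compound is needed, a higher number that more compound is needed for the effect. In this assay compound 3 gives only a limit, > 26000 nM. Compound 1 `CC(=O)Nc1cccc(-c2ccc(C(=O)N(Cc3cccc(OCCCCCC(=O)O)c3)C(C)C)cc2)c1` likewise gives a limit of > 26000 nM in this assay. Compound 2 `CC(C)N(Cc1cccc(OCCCCCC(=O)O)c1)C(=O)c1ccc(-c2cccc(Br)c2)cc1` also gives a limit of > 26000 nM in this assay. All three values thus sit at the limit of > 26000 nM in this assay, at which 3 of the 3 values shown sit, so compound 3 stands exactly where the other two stand, at the edge of what this assay can report. The two steps among the measured compounds, a step that the two limits leave unreadable from compound 1 to compound 2 and a step that the two limits leave unreadable from compound 1 to compound 3, are for that reason unreadable: neither a direction nor a size can be taken from them. Compound 4 `CCOC(=O)CCCCCOc1cccc(CN(C(=O)c2ccc(-c3cnc(OC)nc3OC)cc2)C(C)C)c1` has not been measured yet; it differs from compound 3 by 2,4-dimethoxypyrimidin-5-yl in place of 3-acetamidophenyl on an aromatic carbon. Within the data shown here, no measured step touches a change of this kind, and the steps that exist give no readable size to lean on. The expectation for compound 4 is therefore another limit in this assay, a step of a number no higher from compound 3 to compound 4 (the limit leaves the size open) that cannot be sized, and the estimate is 26000 nM with a range from 10000 nM to 100000 nM.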

Compound 4, half-maximal effective concentration: > 26000 nM
Compound 4 gave a limit, no number (the forecaster's own chance of this, stated with the estimate: 85%); the middle value sits exactly at the limit.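

Compound 3 and compound 4 both give only a limit in this assay, so no step can be read between them: the limit of > 26000 nM in this assay, at which 4 of the 4 values shown sit.

The compounds shown leave open what concentration any of them would need for the effect, and whether 2,4-dimethoxypyrimidin-5-yl in place of 3-acetamidophenyl changes it at all.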